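Cyano in Place of Nitro: What Compound 3 Might Give

The compounds below may be only part of what the source reports. "The series", "measured", "known", "first", "only" and "open" are said of these compounds alone.

Compound 1 `C#CCO/N=C/c1c(-c2ccc(C)cc2)nc2c(C)cccn12` was tested in a functional assay on the whole organism (strain NMRI) with Mus musculus as the target, with a stated time of 0.5 h (on this read-out lower numbers stand for an effect already at smaller amounts and higher numbers for an effect only at larger amounts of compound), where compound 1 gives 20 mg/kg. Compound 2 `Cc1ccc(-c2nc3ccc(Br)cn3c2/C=N/OCc2cn(Cc3ccc([N+](=O)[O-])cc3)nn2)cc1` was tested in the same way; in this assay compound 2 gives 20 mg/kg. On the numbers shown, compound 2 stands level with compound 1 at the digits given, the two values lying within the scatter of each other, so nothing can be said of an order between them.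

Compound 3 `Cc1ccc(-c2nc3ccc(Br)cn3c2/C=N/OCc2cn(Cc3ccc(C#N)cc3)nn2)cc1` has not been measured in this assay. It differs from compound 2 in one place: cyano in place of nitro on an aromatic carbon. Among the measured compounds shown here, no pair of measured compounds differing in a single place exists here, so the size of this kind of step cannot be read from the data; what compound 1 and compound 2 show is only that two rather different structures give the same minimum effective dose.

The step from compound 2 to compound 3 is therefore expected to be small, no change at the digits printed from compound 2 to compound 3 (within the scatter), no larger than the scatter in either direction. Compound 3 is estimated to give 20 mg/kg in this assay, with a range from 10 mg/kg to 40 mg/kg.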

Compound 3, minimum effective dose: 40 mg/kg
Beside the measured number, compound 3's estimate is 2.0-fold (0.30 log units) below it; low and high end bracket the measured number.
By their numbers in this assay, from the lowest: compounds 1, 2 and 3 (each within the scatter of the next).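

Among the compounds shown here, this is the first step that can be read at a single place: with cyano in place of nitro on an aromatic carbon, para to a large group, this assay shows a 2.0-fold higher number from compound 2 to compound 3 (0.30 log units; within the scatter). On this read-out, the exchange of 4-nitrobenzyl for 4-cyanobenzyl therefore cannot be told apart from the usual scatter, whereas compound 1 and compound 2 differed in too many places to speak to this position at all. No measurement accompanies the step that could account for its size or say anything about the two groups beyond their structures.

The compounds shown leave open whether an amine, a carboxylic acid or a methoxy group at the same place would give a step beyond the scatter, or whether the value at this position stays within it whichever group is present. They also leave open whether cyano in place of nitro would read the same way on a different core, such as the core of compound 1, or with a group other than bromo on the shared core.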